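Halogen Position on the Indazole Ring and Cell Potency

A few compounds are considered here, and "the series" means these few. Any claim that something is new, unique, unknown or untested is made for them only; others in the source may bear on it.

Measured so far in a functional assay on MCF7 cells (Homo sapiens) for cytotoxicity, read by CellTiter-Glo, with a stated time of 5 days; a lower number here means a stronger inhibitor, a higher number a weaker inhibitor:
compound 1 `CC/C(=C(/c1ccc(/C=C/C(=O)O)cc1)c1cc2cn[nH]c2cc1F)c1ccccc1`: 47 nM
compound 2 `CC/C(=C(/c1ccc(/C=C/C(=O)O)cc1)c1cc(F)c2[nH]ncc2c1)c1ccccc1`: 7.5 nM

Going by the values given here, compound 2 gives the lowest of the two numbers, and the only measured step, a 6.3-fold lower number from compound 1 to compound 2 (0.80 log units; beyond the scatter), shows how moving the fluorine changed the result. Compound 3 `CC/C(=C(/c1ccc(/C=C/C(=O)O)cc1)c1cc2cn[nH]c2cc1Cl)c1ccccc1` carries 6-chloro-1H-indazol-5-yl in place of 7-fluoro-1H-indazol-5-yl on a double-bonded chain carbon bound to an aromatic carbon and a double-bonded chain carbon, which brings back the 6-substitution of compound 1, now with chlorine instead of fluorine. Among the compounds with values here, only that one step bears on the change, and chlorine has no precedent here. The expected step is a 5.3-fold higher number from compound 2 to compound 3 (0.73 log units; beyond the scatter), toward a higher number. Compound 3 is estimated at 40 nM, with a range from 12 nM to 130 nM.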

Compound 3, half-maximal inhibitory concentration: 137 nM
For compound 3 the middle estimate is 3.4-fold (0.53 log units) below the measured one; the measured number lies above the stated range.
By their numbers in this assay, from the lowest: compound 2; then compound 1; then compound 3.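

Replacing 6-fluoro-1H-indazol-5-yl with 6-chloro-1H-indazol-5-yl gives a 2.9-fold higher number from compound 1 to compound 3 (0.46 log units; beyond the scatter) in this assay, so the choice of halogen matters as well as where it sits. The change from 7-fluoro-1H-indazol-5-yl gives an 18-fold higher number from compound 2 to compound 3 (1.26 log units; beyond the scatter) and leaves compound 3 with the highest number of the three. Nothing measured here explains these differences.

Chlorine appears only as 6-chloro-1H-indazol-5-yl, so its effect in the place held by fluorine in 7-fluoro-1H-indazol-5-yl remains open. Also open, on these data alone, is how a bromo group, or a plain 1H-indazol-5-yl with no halogen, would compare.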